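Swapping cyclohexyl on a rapidly cleared compound

The compounds below may be only part of what the source reports. "The series", "measured", "known", "first", "only" and "open" are said of these compounds alone.

For the measured compounds named here, compound 1 `O=C(NCc1cc(Cl)ccc1-n1cnnn1)[C@@H]1C[C@@H]2C[C@@H]2N1C(=O)[C@H](O)C1CCCCC1` is the only compound here with a true number in an ADME assay on liver for metabolic stability, with Liver microsome (Homo sapiens) as the target, read by LC-MS, using microsomes; a lower number here means slower removal, a higher number faster removal of the compound: compound 1 gives 150 mL.min-1.g-1. Compound 2 `CCCC[C@@H](O)C(=O)N1N=CC[C@H]1C(=O)NCc1cc(Cl)ccc1-n1cnnn1` reports only a limit, < 12 mL.min-1.g-1. Compound 3 `O=C(NCc1cc(Cl)ccc1-n1cnnn1)[C@@H]1[C@H]2C[C@H]2CN1C(=O)[C@H](O)CC1CC1` also reports only a limit, < 14 mL.min-1.g-1. Compound 4 `COC(C)(C)[C@@H](O)C(=O)N1[C@H](C(=O)NCc2cc(Cl)ccc2-n2cnnn2)C[C@@H]2C[C@@H]21` keeps the core of compound 1 and changes one group: 1-methoxy-1-methylethyl in place of cyclohexyl on a saturated chain carbon bound to a carbonyl carbon and an oxygen on a saturated carbon. In words, 1-methoxy-1-methylethyl takes the place of cyclohexyl. Going by the values given here, the expectation rests on compound 1, at 150 mL.min-1.g-1, being the only measured compound with cyclohexyl. The two limits come from compounds that also differ in the core. A clear fall is expected, with an estimated 5.0-fold lower number from compound 1 to compound 4 (0.70 log units; beyond the scatter). For compound 4 the estimate is 30 mL.min-1.g-1, with an expected range of 10 mL.min-1.g-1 to 90 mL.min-1.g-1.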

Compound 4, intrinsic clearance in microsomes: 40 mL.min-1.g-1
Beside the measured number, compound 4's estimate is 1.3-fold (0.12 log units) below it; low and high end bracket the measured number.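

On the unchanged core, this position alone moves the number in this assay: replacing cyclohexyl with 1-methoxy-1-methylethyl gives a 3.8-fold lower number from compound 1 to compound 4 (0.57 log units; beyond the scatter) and lies beyond the usual scatter. The earlier compounds shown here could not show this, as each of the others differs from compound 1 in the core as well. Nothing measured here explains why the number falls.

The compounds shown leave open whether the fall follows from losing the ring or from gaining the oxygen. A tert-butyl group or a tetrahydropyranyl ring at this position would help separate the two.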